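A few compounds are considered here, and "the series" means these few. Any claim that something is new, unique, unknown or untested is made for them only; others in the source may bear on it.

In a functional assay on MCF7 cells (Homo sapiens) for antiproliferative activity, read by MTT assay, with a stated time of 72 h (on this read-out higher numbers stand for weaker inhibition and lower numbers for stronger inhibition), compound 1 `COc1ccccc1-c1ccc2ncn(-c3cc(OC)c(OC)c(OC)c3)c2c1` gives 1750 nM. Compound 2 `COc1cc(-n2cnc3ccc(-c4ccccc4Cl)cc32)cc(OC)c1OC` reaches only the assay limit, > 10000 nM (the limit of > 10000 nM in this assay, at which 1 of the 3 values shown sits). Compound 3 `COc1cc(-n2cnc3ccc(-c4ccc(C)cc4F)cc32)cc(OC)c1OC` gives 56 nM, the lowest of the two numbers, compound 1 being nearest. The steps of a 31-fold lower number from compound 1 to compound 3 (1.49 log units; beyond the scatter) and an at least 170-fold lower number from compound 2 to compound 3 (2.25 log units; beyond the scatter) show that the aryl group on this carbon of the shared core moves the read-out strongly in both directions. Compound 4 `COc1cc(-n2cnc3ccc(-c4cccc(N)c4)cc32)cc(OC)c1OC` differs from compound 3 by 3-aminophenyl in place of 2-fluoro-4-methylphenyl on an aromatic carbon. Among the measured compounds shown here, those two steps bear on it: every change of this aryl group so far was large, and no measured compound carries anything like 3-aminophenyl, so a large weakening step is expected, a 14-fold higher number from compound 3 to compound 4 (1.15 log units; beyond the scatter), with wide uncertainty. Compound 4 is therefore estimated at 800 nM, within 100 nM to 6000 nM.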

Compound 4, half-maximal inhibitory concentration: 180 nM
Compound 4: middle estimate off by 4.4-fold (0.65 log units), on the high side; measured number inside the range.
By their numbers in this assay, from the lowest: compound 3; then compound 4; then compound 1. At a limit, above all of these: compound 2.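

On this carbon, an aryl group carrying a hydrogen-bond donor and acceptor is compatible with a low number in this assay, at a modest cost against 2-fluoro-4-methylphenyl: a 3.2-fold higher number from compound 3 to compound 4 (0.51 log units; beyond the scatter). The 3-aminophenyl group also improves on both other aryl groups, with a 9.7-fold lower number from compound 1 to compound 4 (0.99 log units; beyond the scatter) and an at least 55-fold lower number from compound 2 to compound 4 (1.74 log units; beyond the scatter). The value of compound 2 is a limit, not a number: the limit of > 10000 nM in this assay, at which 1 of the 4 values shown sits.

As far as these compounds go, whether the amine itself matters remains open, as a plain phenyl, a hydroxyl or a carboxylic acid in its place would show. The separate contributions of the fluoro and methyl groups of compound 3 also remain unresolved.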